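Moving the Methoxy Group: An Estimate for Compound 4

The source may hold more compounds than are shown below. What is called first, only, known or untested is meant among the compounds shown, and "the series" means these compounds.

Of the compounds shown here, three sharing one core have been tested. Compound 1 `COc1ccccc1Nc1nnc(Nc2nc(-c3ccc([N+](=O)[O-])cc3)cs2)s1` carries a 2-methoxyphenyl group and a nitro group; in a functional assay on the whole organism (strain albino) with Mus musculus as the target, in the maximal electroshock model, with a stated time of 0.5 h (on this read-out lower numbers stand for an effect already at smaller amounts and higher numbers for an effect only at larger amounts of compound), compound 1 gives 300 mg/kg. Compound 2 `COc1ccc(Nc2nnc(Nc3nc(-c4ccc([N+](=O)[O-])cc4)cs3)s2)cc1` differs from compound 1 by 4-methoxyphenyl in place of 2-methoxyphenyl on a nitrogen on an aromatic ring, and in this assay compound 2 gives 30 mg/kg, the step being a 10-fold lower number from compound 1 to compound 2 (1.00 log units; beyond the scatter). Compound 3 `COc1ccccc1Nc1nnc(Nc2nc(-c3ccccc3)cs2)s1` differs from compound 1 by hydrogen in place of nitro on an aromatic carbon, and in this assay compound 3 gives 100 mg/kg, a step of a 3.0-fold lower number from compound 1 to compound 3 (0.48 log units; beyond the scatter).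

Compound 4 `COc1ccc(Nc2nnc(Nc3nc(-c4ccccc4)cs3)s2)cc1` has not yet been measured in this assay. It differs from compound 3 by 4-methoxyphenyl in place of 2-methoxyphenyl on a nitrogen on an aromatic ring, the same change that turns compound 1 into compound 2: in both cases the group sits on a nitrogen on an aromatic ring whose other neighbours are aromatic carbon. The two cores on which the change is made differ by hydrogen in place of nitro on an aromatic carbon.

Among the measured compounds shown here, only one measured instance of this change exists, and it rests on a single pair. For the measured compounds named here, the step to compound 4 is expected to be a 10-fold lower number from compound 3 to compound 4 (1.00 log units; beyond the scatter), because a 10-fold lower number from compound 1 to compound 2 (1.00 log units; beyond the scatter) is the only measured example of the same change and nothing among the three measured compounds speaks against repeating it. Compound 4 is therefore estimated at 10 mg/kg in this assay. Compound 4 is expected to fall between 5 mg/kg and 30 mg/kg.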

Compound 4, minimum effective dose: 100 mg/kg
Compound 4: the middle estimate sits 10-fold (1.00 log units) below what was measured; the measured number lies above the stated range.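

In this assay, the change from 2-methoxyphenyl to 4-methoxyphenyl on the core without the nitro group gives no change at the digits printed from compound 3 to compound 4 (within the scatter), so the step seen on the nitro-bearing core does not carry over to this core, and the two steps differ: the same change on two cores in this assay, a 10-fold lower number (1.00 log units; beyond the scatter) from compound 1 to compound 2 and no change at the digits printed (within the scatter) from compound 3 to compound 4, 10-fold (1.00 log units) apart, beyond the scatter of two such steps. The same four compounds can be read the other way, and hydrogen in place of nitro on an aromatic carbon, which lowered the number on the 2-methoxyphenyl core, now gives a 3.3-fold higher number from compound 2 to compound 4 (0.52 log units; beyond the scatter), so that change also depends on the core that carries it: the same change on two cores in this assay, a 3.0-fold lower number (0.48 log units; beyond the scatter) from compound 1 to compound 3 and a 3.3-fold higher number (0.52 log units; beyond the scatter) from compound 2 to compound 4, 10-fold (1.00 log units) apart, beyond the scatter of two such steps. This shows that in these four compounds the two changes do not act independently of each other, but it does not show why, and with a single pair on each core it sets no rule for the rest of the series.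

As far as these compounds go, it remains open whether an amine, a nitrile or a chlorine in place of the nitro group would behave like the nitro group or like hydrogen when the methoxy group is moved. From the compounds shown here alone, it is also open whether an ethoxy group or a longer alkoxy chain in place of the methoxy group would show the same dependence on the core.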